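Chloro added beside methoxy on the aryl ring

This account rests on a few compounds, and the source may have more. Where it says the series, first, only, none or still open, it means among the compounds named here.

Three members of the series have been measured in a functional assay on CHO cells for positive allosteric modulation of metabotropic glutamate receptor 2 (Homo sapiens), read by scintillation counting and GTPgammaS binding, with a stated time of 30 min; a lower number here means a smaller maximal response, a higher number a larger maximal response. Compound 1 `COc1ccc(-c2ccn(CCC(C)C)c(=O)c2C#N)cc1` gives 160% there. Compound 2 `COc1cccc(-c2ccn(CCC(C)C)c(=O)c2C#N)c1` gives 176%, and compound 3 `COc1ccccc1-c1ccn(CCC(C)C)c(=O)c1C#N` gives 120%. Compound 1 thus stands second of the three numbers: compound 2 lies higher by an amount beyond the usual scatter, while compound 3 lies well lower, also beyond the scatter. The three differ only in where the methoxy group sits on the aryl ring, and the methoxy placement of compound 1 sits between the other two in the maximal response.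

Compound 4 `COc1ccc(-c2ccn(CCC(C)C)c(=O)c2C#N)cc1Cl` is not yet measured. It differs from compound 1 in one place: chloro in place of hydrogen on an aromatic carbon. The chloro enters on an aromatic carbon, ortho to a methoxy group and meta to a large group. Within the data shown here, no measured pair shows the effect of such an addition, so the direction of the step can only be guessed. A small step is expected in this assay, most likely within the scatter, with a slight lean upward because compound 1 already gives 160% and compound 2 shows that the high end of this range is reachable at 176%. The expected step is a number 5 percentage points higher from compound 1 to compound 4 (within the scatter).

For compound 4 the estimate is 165%, with a range from 130% to 200%.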

Compound 4, largest response reached (Emax), in percent of the reference or control that the assay uses: 200%
Estimate against measurement, compound 4: 35 percentage points below; low and high end bracket the measured number.
By their numbers in this assay, from the lowest: compound 3; then compound 1; then compound 2; then compound 4.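

In this assay, chloro in place of hydrogen on an aromatic carbon, ortho to a methoxy group and meta to a large group, gives a number 40 percentage points higher from compound 1 to compound 4 (beyond the scatter). The earlier compounds shown here varied only the placement of the methoxy group, whereas this pair shows that the aryl ring accepts a further substituent and that a single added heavy atom at this carbon is enough to shift the maximal response by a large step. Nothing at hand explains why this change has so large an effect on the response.

The compounds shown leave open whether the step belongs to chloro itself or would also come with fluoro, bromo or a methyl group on the same carbon, and whether it carries over to the methoxy placements of compound 2 and compound 3. They also leave open whether the step persists when an ethoxy group or a hydroxyl group stands in place of the methoxy group, and whether the change in maximal response is accompanied by any change in the concentration needed to reach it.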